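The source may report more compounds than this note shows. Statements on the series, on what has been measured and on what is new or still open speak of the compounds shown alone.

Measured so far:
Compound 1, `COc1cc(-c2nnc3n2NC(c2ccco2)C(C(=O)c2ccccc2F)S3)cc(OC)c1OC`, in a functional assay on MCF7 cells (Homo sapiens) for cytotoxicity, read by MTT assay, with a stated time of 48 h; a higher number here means a weaker inhibitor, a lower number a stronger inhibitor: 94800 nM.
Compound 2, `COc1cc(-c2nnc3n2NC(c2ccco2)C(C(=O)c2ccc(C)cc2)S3)cc(OC)c1OC`, in this assay: > 100000 nM, which is a limit of the assay rather than a number.

Compound 2 therefore stands at the edge of what this assay can report: its result is the limit of > 100000 nM in this assay, at which 1 of the 2 values shown sits, not a measured number. Its neighbour compound 1 gives 94800 nM, and the step of an at least 1.0-fold higher number from compound 1 to compound 2 (0.02 log units; that floor lies within the scatter) lies within the scatter, so the two compounds cannot be told apart on these numbers; both are very weak inhibitors at best.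

Compound 3, `COc1cc(-c2nnc3n2NC(c2ccco2)C(C(=O)c2ccc(C(F)(F)F)cc2)S3)cc(OC)c1OC`, has not yet been measured in this assay. It differs from compound 2 by trifluoromethyl in place of methyl on an aromatic carbon. Among the compounds with values here, the one measured step available, an at least 1.0-fold higher number from compound 1 to compound 2 (0.02 log units; that floor lies within the scatter), also swaps one group on the same carbonyl-bearing ring and shows no movement beyond the scatter, and that is the only guide here. With both measured compounds at or near the limit, the expectation for compound 3 is a result in the same region, the step of a number no higher from compound 2 to compound 3 (the limit leaves the size open) being expected to stay within the scatter. Compound 3 is estimated at 100000 nM, with a range from 40000 nM to 250000 nM, and a substantial chance that only the limit is reported again.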

Compound 3, half-maximal inhibitory concentration: 33600 nM
Compound 3: the middle estimate sits 3.0-fold (0.47 log units) above what was measured; the measured number lies below the stated range.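

Within the data shown here, the group on this ring can move the result after all: in this assay, placing trifluoromethyl instead of methyl, para to a large group, gives an at least 2.9-fold lower number from compound 2 to compound 3 (0.47 log units; beyond the scatter), and this step lies beyond the scatter, unlike the one earlier step. The comparison with the 2-fluorophenyl group points the same way, since replacing it with 4-(trifluoromethyl)phenyl gives a 2.8-fold lower number from compound 1 to compound 3 (0.45 log units; beyond the scatter), so compound 3 stands apart from both of its measured neighbours. Compound 2 carries a limit and not a number, so the step that starts from it gives only a floor for the change: the limit of > 100000 nM in this assay, at which 1 of the 3 values shown sits.

Going by these compounds, what remains open is whether this gain belongs to trifluoromethyl in particular or would also appear with a chlorine atom, a nitrile or a methoxy group at the same place on the ring. Three compounds also cannot show whether changes at this ring or elsewhere on the shared core could take compound 3, which gives 33600 nM and is still a weak inhibitor, to a much lower number.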